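Compound 3 to compound 4: a small change to the ester

The source may hold more compounds than are shown below. What is called first, only, known or untested is meant among the compounds shown, and "the series" means these compounds.

Measured in an ADME assay on HepG2 2.2.15 cells (Homo sapiens) for cytotoxicity; on this read-out lower numbers stand for higher toxicity in this test and higher numbers for lower toxicity in this test:
- compound 1 `CC(=O)OCC(=O)OCCc1c(-c2ccccc2Cl)c2cc(Cl)ccc2[nH]c1=O` gives 100000 nM
- compound 2 `COc1ccc(/C=C/C(=O)OCCc2c(-c3ccccc3Cl)c3cc(Cl)ccc3[nH]c2=O)cc1OC` gives > 1200000 nM (a limit of the assay, not a number)
- compound 3 `C/C=C/C(=O)OCCc1c(-c2ccccc2Cl)c2cc(Cl)ccc2[nH]c1=O` gives 30000 nM

In this assay compound 3 gives 30000 nM, the lower of the two actual numbers in the series. Compound 1 is the nearest value, with a 3.3-fold lower number from compound 1 to compound 3 (0.52 log units; beyond the scatter) and this gap lying beyond the scatter. Compound 2 has only a limit, > 1200000 nM, and no number.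

Compound 4 `C/C=C(\C)C(=O)OCCc1c(-c2ccccc2Cl)c2cc(Cl)ccc2[nH]c1=O` has 1-methylprop-1-en-1-yl in place of prop-1-en-1-yl on a carbonyl carbon. Only the measured steps at or near this carbonyl carbon bear on the change. They are an at least 12-fold higher number from compound 1 to compound 2 (1.07 log units; beyond the scatter), a 3.3-fold lower number from compound 1 to compound 3 (0.52 log units; beyond the scatter) and an at least 40-fold lower number from compound 2 to compound 3 (1.60 log units; beyond the scatter). The two steps involving compound 2 are large, and the step between compound 1 and compound 3 is modest. All three exchange far more different groups than the present change does, and none tests this exact exchange, so they serve only as a loose guide.

A small change in this assay is therefore expected, with no firm direction. The expected step is a 1.3-fold higher number from compound 3 to compound 4 (0.12 log units; within the scatter) and would stay within the scatter. For compound 4 the estimated value is 40000 nM, with an expected range from 14000 nM to 120000 nM.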

Compound 4, half-maximal cytotoxic concentration: 350000 nM
Estimate against measurement, compound 4: 8.8-fold (0.94 log units) below; measured number above the stated range.
By their numbers in this assay, from the lowest: compound 3; then compound 1; then compound 4. At a limit, above all of these: compound 2.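

In this assay, among the compounds shown here, a 12-fold higher number from compound 3 to compound 4 (1.07 log units; beyond the scatter), so one added methyl on the prop-1-en-1-yl group, on a carbonyl carbon, is enough for a large step; the earlier steps at this place all exchanged far more different groups. Compound 1 now falls between two close analogues, since a 3.5-fold higher number from compound 1 to compound 4 (0.54 log units; beyond the scatter) puts compound 4 on the opposite side of compound 1 from compound 3, and the read-out at this position cannot be ordered by the degree of structural change alone. Compound 2 remains a limit and not a number, so an at least 3.4-fold lower number from compound 2 to compound 4 (0.53 log units; beyond the scatter) is only a bound and the true gap stays unknown: the limit of > 1200000 nM in this assay, at which 1 of the 4 values shown sits.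

The compounds shown do not separate an effect of the added methyl itself from an effect of where it sits on the double-bonded chain, and a saturated butyl chain or a longer alkenyl chain on the same carbonyl carbon would bear on this. From the compounds shown here alone, how an amine or a carboxylic acid at the end of such a chain would read in this assay also remains open.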